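This account rests on a few compounds, and the source may have more. Where it says the series, first, only, none or still open, it means among the compounds named here.

Compound 1 `COc1ccc(F)cc1Nc1cc(NC(=O)Nc2c(Cl)cccc2Cl)ncn1` and compound 2 `COc1cc(Br)ccc1Nc1cc(NC(=O)Nc2c(Cl)cccc2Cl)ncn1` share one core and differ only in the ring attached to a nitrogen on an aromatic ring. In a functional assay on HCC827 cells (Homo sapiens) for inhibition, read by MTT assay, with a stated time of 48 h, tested at 10 uM (on this read-out higher numbers stand for more inhibition at the one concentration tested (going by the name of the read-out) and lower numbers for less inhibition), compound 1 gives 78%, while compound 2 gives 42.7%, the lower of the two numbers; the step of a number 35.3 percentage points lower from compound 1 to compound 2 (beyond the scatter) shows how much that single exchange of rings moved the read-out.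

Compound 3 `COc1ccc(Nc2cc(NC(=O)Nc3c(Cl)cccc3Cl)ncn2)cc1C` is not yet measured. It differs from compound 2 by 4-methoxy-3-methylphenyl in place of 4-bromo-2-methoxyphenyl on a nitrogen on an aromatic ring. Among the measured compounds shown here, only the one measured step bears on this change, and it shows that swapping the substituted ring at this position can shift the read-out by a large amount in either direction. Compound 3 is therefore expected to move back upward, with a step of a number 12.3 percentage points higher from compound 2 to compound 3 (beyond the scatter), though with wide uncertainty. The estimate for compound 3 is 55%, within a range from 25% to 85%.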

Compound 3, a percentage reported as inhibition, at one concentration (the size of the read-out at that concentration, not a potency): 63.1%
Compound 3: the middle estimate sits 8.1 percentage points below what was measured, within the range that was stated.
By their numbers in this assay, from the lowest: compound 2; then compound 3; then compound 1.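

In this assay, the step of a number 20.4 percentage points higher from compound 2 to compound 3 (beyond the scatter) shows that the read-out at this position does not depend on ring size alone: 4-methoxy-3-methylphenyl and 4-bromo-2-methoxyphenyl have the same heavy-atom count and still give clearly different numbers. The step of a number 14.9 percentage points lower from compound 1 to compound 3 (beyond the scatter) shows that this new ring does not match 5-fluoro-2-methoxyphenyl either, so the three rings give three separate levels, each beyond the scatter of the others. No supporting data are available to explain these differences.

Each exchange alters more than one substituent on the ring at once, so the contribution of the methyl, the halogen or the placement of the methoxy cannot be separated. Also open, as far as these compounds go, is how this position would respond to a ring carrying an amine, a carboxylic acid or a longer chain.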